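This account rests on a few compounds, and the source may have more. Where it says the series, first, only, none or still open, it means among the compounds named here.

Of the compounds shown here, two have so far been tested in a functional assay (strain AB) with Danio rerio as the target, read by microscopy, with a stated time of 1 h; on this read-out lower numbers stand for an effect already at smaller amounts and higher numbers for an effect only at larger amounts of compound. Compound 1, `CCN1CCc2c(sc(N)c2C(N)=O)C1`, gives > 25000 nM in this assay, which is a limit of the assay rather than a measured number. Compound 2, `CC(C)(C)OC(=O)CN1CCc2c(sc(NC(=O)Nc3ccc(Cl)cc3)c2C(N)=O)C1`, gives > 25000 nM in this assay, again a limit and not a number. Within the data shown here, compound 2 thus stands at the limit of > 25000 nM in this assay, at which 2 of the 2 values shown sit, and no measured step between compounds exists. Compound 3, `CCCN1CCc2c(sc(NC(=O)Nc3ccc(Cl)cc3)c2C(N)=O)C1`, has not yet been tested. It differs from compound 2 in one place: ethyl in place of tert-butoxycarbonyl on a saturated chain carbon bound to an amine nitrogen in a ring. With both measured compounds at the limit, no step beyond the usual scatter is expected from this change, in either direction. Compound 3 is expected to give about 40000 nM in this assay, with a plausible range from 10000 nM to 200000 nM. This corresponds to an estimated step that the limit leaves unreadable from compound 2 to compound 3, and a limit rather than a number remains the most likely outcome.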

Compound 3, half-maximal effective concentration: 3500 nM
For compound 3 the middle estimate is 11-fold (1.06 log units) above the measured one; measured number below the stated range.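

The group on the ring amine nitrogen turns out to matter for this read-out, which the two earlier compounds could not show while both sat at the limit. In this assay, among these compounds, replacing (tert-butoxycarbonyl)methyl with propyl at this place, with the rest of the molecule unchanged, gives an at least 7.1-fold lower number from compound 2 to compound 3 (0.85 log units; beyond the scatter), and compound 3 is the first compound here with a real number rather than a limit. Compound 2 has only a limit, so the true step may be larger than the printed one: the limit of > 25000 nM in this assay, at which 2 of the 3 values shown sit.

The compounds shown cannot tell whether removing the tert-butoxycarbonyl group or adding the plain propyl chain matters more. They also leave open how a longer chain, or a chain ending in a carboxylic acid or an amine, would behave at this place.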